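The source may hold more compounds than are shown below. What is called first, only, known or untested is meant among the compounds shown, and "the series" means these compounds.

Measured so far: compound 1 `CCOc1ncc(-c2nc(C(F)(F)F)sc2N2CCN(C(=O)Cn3nc(C)nc3C)[C@H](C)C2)cn1` with 173 nM; compound 2 `COc1ncc(-c2nc(C(F)(F)F)sc2N2CCN(C(=O)Cn3nc(C)nc3C)[C@H](C)C2)cn1` with 558 nM; compound 3 `CCCc1ncc(-c2nc(C(F)(F)F)sc2N2CCN(C(=O)Cn3nc(C)nc3C)[C@H](C)C2)cn1` with 258 nM.

In a functional assay on U2OS cells for antagonist activity at C-X-C chemokine receptor type 3 (Homo sapiens), read by beta-arrestin recruitment (a higher number here means a weaker inhibitor, a lower number a stronger inhibitor), compound 3 stands second highest of the three numbers, with compound 1 nearest to it and compound 2 furthest away. Compound 4 `Cc1nc(C)n(CC(=O)N2CCN(c3sc(C(F)(F)F)nc3-c3cnc(C(C)(C)C)nc3)C[C@H]2C)n1` differs from compound 3 by tert-butyl in place of propyl on an aromatic carbon. Within the data shown here, two measured steps touch the same aromatic carbon: a 1.5-fold higher number from compound 1 to compound 3 (0.17 log units; within the scatter) and a 2.2-fold lower number from compound 2 to compound 3 (0.34 log units; beyond the scatter). Only the second of these was beyond the scatter, and both were modest. On that basis compound 4 is expected to show no step beyond the scatter in this assay, that is a 1.0-fold lower number from compound 3 to compound 4 (0.01 log units; within the scatter). Compound 4 is therefore estimated at 250 nM, with a range from 100 nM to 650 nM.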

Compound 4, half-maximal inhibitory concentration: 1030 nM
Estimate against measurement, compound 4: 4.1-fold (0.61 log units) below; the measured number lies above the stated range.
By their numbers in this assay, from the lowest: compounds 1 and 3 (each within the scatter of the next); then compounds 2 and 4 (each within the scatter of the next).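

In this assay, the aromatic carbon between two ring nitrogen atoms distinguishes even two all-carbon groups, since replacing propyl with tert-butyl gives a 4.0-fold higher number from compound 3 to compound 4 (0.60 log units; beyond the scatter). Replacing ethoxy with tert-butyl gives a 6.0-fold higher number from compound 1 to compound 4 (0.77 log units; beyond the scatter), while replacing methoxy with tert-butyl gives a 1.8-fold higher number from compound 2 to compound 4 (0.27 log units; within the scatter), so tert-butyl cannot be told apart from methoxy here. Nothing available explains this change. The compounds shown leave open whether isopropyl, a branched chain with fewer carbons than tert-butyl, would stay with propyl or with tert-butyl. They also leave open how a dimethylamino group would read at this carbon.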